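The source may report more compounds than this note shows. Statements on the series, on what has been measured and on what is new or still open speak of the compounds shown alone.

Measured so far:
- Compound 1 `CCCSc1nc(N/N=C(\C)c2ccc(OC)cc2)c2nnn(Cc3ccccc3)c2n1`, which in a functional assay on MCF7 cells (Homo sapiens) for antiproliferative activity, read by MTT assay, with a stated time of 72 h (on this read-out higher numbers stand for weaker inhibition and lower numbers for stronger inhibition), gives only a limit, > 64000 nM.
- Compound 2 `CCCSc1nc(N/N=C/c2ccccc2F)c2nnn(Cc3ccccc3)c2n1`, which in this assay likewise gives only a limit, > 64000 nM.
- Compound 3 `CCCSc1nc(N/N=C(\C)c2ccccc2O)c2nnn(Cc3ccco3)c2n1`, which in this assay gives 29000 nM.

All three share a core carrying a propylthio group and a hydrazone arm. For compound 2 this assay reports a limit rather than a number, and that limit is shared with one other value, as the limit of > 64000 nM in this assay, at which 2 of the 3 values shown sit, shows. Compound 3 is the only one of the three that gives an actual number, and that number is weak inhibition. No pair of these compounds differs in a single place, so no measured step can be drawn between them.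

Compound 4 `CCCSc1nc(N/N=C/c2ccccc2Cl)c2nnn(Cc3ccccc3)c2n1` is not yet measured. It differs from compound 2 only in a halogen swap: chloro in place of fluoro on an aromatic carbon. With compound 2 sitting at a limit, the size of this step cannot be read from the shown values; the expected change in this assay from compound 2 to compound 4 is small, an at least 1.0-fold lower number from compound 2 to compound 4 (0.02 log units; that floor lies within the scatter), and probably within the scatter. Compound 4 is therefore estimated to give about 60000 nM, somewhere between 20000 nM and 150000 nM, with a fair chance that only a limit is reported.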

Compound 4, half-maximal inhibitory concentration: 13800 nM
Compound 4: middle estimate off by 4.3-fold (0.64 log units), on the high side; the whole stated range lies above it.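

Replacing the 2-fluorophenyl with a 2-chlorophenyl changes a single heavy atom, on an aromatic carbon ortho to a large group, and in this assay it gives an at least 4.6-fold lower number from compound 2 to compound 4 (0.66 log units; beyond the scatter). Among the compounds shown here, this pair therefore shows that, at this position and with the rest of the molecule unchanged, the choice of halogen alone can move the result beyond the usual scatter, something the earlier compounds could not show. Before this, the only actual number was that compound 3 gives 29000 nM, and no single change could be tied to any difference. The true size of the new step remains unknown because compound 2 gives only a limit: the limit of > 64000 nM in this assay, at which 2 of the 4 values shown sit.

The compounds shown leave open whether a bromo or a methyl group at this place, or a plain hydrogen, would give a number nearer that of compound 2 or compound 4. This one pair also cannot tell whether the same swap would act alike in a compound with a methyl on the hydrazone carbon, the feature seen in compound 1.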